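Inverting One Stereocentre of a Furan-Bearing Alcohol

The source may report more compounds than this note shows. Statements on the series, on what has been measured and on what is new or still open speak of the compounds shown alone.

In a functional assay on HeLa cells (Homo sapiens) for antiproliferative activity, read by XTT assay, with a stated time of 72 h (a higher number here means a weaker inhibitor, a lower number a stronger inhibitor), compound 1 (`C=C(C)CCC[C@]1(C)C2=CCC[C@](C)(CC(=O)c3ccoc3)[C@H]2CC[C@H]1C`) gives > 100000 nM, and this is a limit of the assay, not a number. For the measured compounds named here, compound 2 (`C=C(C)CCC[C@]1(C)C2=CCC[C@](C)(C[C@@H](O)c3ccoc3)[C@H]2CC[C@H]1C`) gives 59400 nM, the only true number so far. Going by the values given here, the one measured step, an at least 1.6-fold lower number from compound 1 to compound 2 (0.22 log units; that floor lies within the scatter), puts (furan-3-yl)(hydroxy)methyl in place of (furan-3-yl)carbonyl, and its floor lies within the scatter. From the compounds shown here alone, that step starts from the limit of > 100000 nM in this assay, at which 1 of the 2 values shown sits, so its full size is unknown.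

Compound 3 (`C=C(C)CCC[C@]1(C)C2=CCC[C@](C)(C[C@H](O)c3ccoc3)[C@H]2CC[C@H]1C`) is a close relative of compound 2: the two compounds have the same atoms and bonds and differ only in configuration as drawn: 1 of 5 stereo elements differ; a stereocentre at a saturated chain carbon is drawn R in compound 2 and S in compound 3. A stereocentre at a saturated chain carbon is drawn R in compound 2 and S in compound 3. Among the compounds with values here, the measured step changed a group, not a configuration, so no measured pair shows what this kind of change does. No shift beyond the scatter is therefore expected in this assay, and the expectation stays anchored on compound 2 at 59400 nM. The expected change is a 1.0-fold higher number from compound 2 to compound 3 (0.00 log units; within the scatter). For compound 3 the estimated value is 60000 nM, with an expected range of 25000 nM to 100000 nM.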

Compound 3, half-maximal inhibitory concentration: 59400 nM
The estimate for compound 3 lay 1.0-fold (0.00 log units) above the measured number; the measured number falls inside the stated range.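

In this assay the inversion gives no change at the digits printed from compound 2 to compound 3 (within the scatter), the first measured answer for a change of configuration at this position, and it is a clean reading of that single stereocentre: the fact that compounds 2 and 3 differ only in the configuration as drawn. The same swap of groups, now read with the other alcohol, gives an at least 1.6-fold lower number from compound 1 to compound 3 (0.22 log units; that floor lies within the scatter), so the two alcohols show the same floor against the ketone of compound 1 and neither configuration stands apart in this comparison. From the compounds shown here alone, compound 1 sits at a limit of the assay and not at a number, so the full size of that step stays unknown: the limit of > 100000 nM in this assay, at which 1 of the 3 values shown sits.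

The compounds shown do not tell whether the hydroxyl group itself matters at this carbon, which an amine or a methyl ether in its place could test, or whether the furan-3-yl ring matters, which a phenyl ring could test. They also leave open whether configuration at this carbon would count in a compound with a much lower number, as both alcohols here have high numbers in this assay.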